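A few compounds are considered here, and "the series" means these few. Any claim that something is new, unique, unknown or untested is made for them only; others in the source may bear on it.

Compound 3 `COc1cc(Cc2nc3c(N)ncnc3n2CC(C)C)cc(OC)c1OC` is the weakest inhibitor of the three measured compounds: in a functional assay on MCF7 cells (Homo sapiens) for antiproliferative activity (a higher number here means a weaker inhibitor, a lower number a stronger inhibitor), compound 3 gives 97700 nM, while compound 2 `C#CCCn1c(Cc2cc(OC)c(OC)c(OC)c2)nc2c(N)nc(F)nc21` gives 25100 nM and compound 1 `COc1cc(Cc2nc3c(N)nc(F)nc3n2CC2CCCO2)cc(OC)c1OC` gives 22900 nM, both gaps lying beyond the scatter. Compound 4 `COc1cc(Cc2nc3c(N)ncnc3n2CC(OC)OC)cc(OC)c1OC` differs from compound 3 by dimethoxymethyl in place of isopropyl on a saturated chain carbon bound to an aromatic nitrogen. Among the measured compounds shown here, the only measured step at the same place is a 1.1-fold higher number from compound 1 to compound 2 (0.04 log units; within the scatter), so exchanging the chain on that carbon has so far left this assay unmoved; compounds 1 and 2 also differ from compound 3 elsewhere, and no measured step isolates that difference. The step to compound 4 is therefore expected to stay within the scatter, a 1.4-fold lower number from compound 3 to compound 4 (0.14 log units; within the scatter). Compound 4 is estimated at 70000 nM, with a range of 25000 nM to 200000 nM.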

Compound 4, half-maximal inhibitory concentration: 72400 nM
The estimate for compound 4 lay 1.0-fold (0.01 log units) below the measured number, and the stated range covers the measured number.
By their numbers in this assay, from the lowest: compounds 1 and 2 (each within the scatter of the next); then compounds 4 and 3 (each within the scatter of the next).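

With dimethoxymethyl in place of isopropyl on a saturated chain carbon bound to an aromatic nitrogen, this assay shows a 1.3-fold lower number from compound 3 to compound 4 (0.13 log units; within the scatter) on the core of compound 3. The entering group brings two oxygen atoms and two hydrogen-bond acceptors, yet the step stays within the scatter, so this position has now tolerated an exchange on a second core. Nothing on hand gives a reason for this result. On these data alone, whether an amine, a carboxylic acid or a longer chain on that carbon would move the number remains open. Among the compounds shown here, no step isolates the difference between the cores of compound 1 and compound 3.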